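Methoxy for chloro on the benzoyl ring, two cores

A few compounds are considered here, and "the series" means these few. Any claim that something is new, unique, unknown or untested is made for them only; others in the source may bear on it.

Compound 1 `O=C(CN1CCN(C(=O)c2ccc(Cl)cc2)CC1)N1CCN(CCCc2c[nH]c3ccccc23)CC1` is the reference. In an ADME assay on HEK293 cells (Homo sapiens) for cytotoxicity, read by MTT assay, with a stated time of 72 h (on this read-out lower numbers stand for stronger inhibition and higher numbers for weaker inhibition), compound 1 gives 98200 nM. Compound 2 `COc1ccc(C(=O)N2CCN(CC(=O)N3CCN(CCCc4c[nH]c5ccccc45)CC3)CC2)cc1` carries the change (methoxy in place of chloro on an aromatic carbon); in this assay compound 2 gives 156000 nM, and the step of a 1.6-fold higher number from compound 1 to compound 2 (0.20 log units; within the scatter) is small.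

Compound 3 `O=C(CN1CCN(C(=O)c2cccc(Cl)c2)CC1)N1CCN(CCCc2c[nH]c3ccc(F)cc23)CC1` sits on a second core; the difference between the two cores is not broken down here. In this assay compound 3 gives 66200 nM, which lies within the scatter of compound 1 and beyond it relative to compound 2.

Compound 4 `COc1cccc(C(=O)N2CCN(CC(=O)N3CCN(CCCc4c[nH]c5ccc(F)cc45)CC3)CC2)c1` is not yet measured. It differs from compound 3 by methoxy in place of chloro on an aromatic carbon. This is the same kind of change as that from compound 1 to compound 2, though not the same: there the methoxy sits para to a large group, here meta to a large group.

For the measured compounds named here, with only one earlier example, the expected step is a 1.5-fold higher number from compound 3 to compound 4 (0.18 log units; within the scatter), resting on the step of a 1.6-fold higher number from compound 1 to compound 2 (0.20 log units; within the scatter) being within the scatter. Compound 4 is therefore estimated at 100000 nM, between 50000 nM and 200000 nM.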

Compound 4, half-maximal inhibitory concentration: 87100 nM
Compound 4: the middle estimate sits 1.1-fold (0.06 log units) above what was measured, within the range that was stated.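

In this assay, methoxy in place of chloro gives a 1.3-fold higher number from compound 3 to compound 4 (0.12 log units; within the scatter), and set beside the earlier step, the change reads alike on both cores: the same change on two cores in this assay, a 1.6-fold higher number (0.20 log units; within the scatter) from compound 1 to compound 2 and a 1.3-fold higher number (0.12 log units; within the scatter) from compound 3 to compound 4, 1.2-fold (0.08 log units) apart, within the scatter of two such steps. Both steps lie within the scatter, so on these two cores the exchange leaves the read-out without a resolved shift, and the pair gives no sign that the core alters the outcome. For the compounds shown here, this does not show that the core plays no part, since only two pairs are available, steps this small could hide a modest dependence on the core, and the two pairs also differ in where the methoxy sits, with the second meta to a large group.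

The compounds shown leave open whether any replacement for chloro on this ring gives a step beyond the scatter, for example an amine, a carboxylic acid or a longer alkoxy chain in place of methoxy. They also leave open whether the two positions on the ring would behave alike on a single core.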